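The compounds below may be only part of what the source reports. "The series", "measured", "known", "first", "only" and "open" are said of these compounds alone.

Measured so far in a functional assay on HepG2 cells (Homo sapiens) for antiproliferative activity, read by MTT assay, with a stated time of 48 h; a lower number here means a stronger inhibitor, a higher number a weaker inhibitor:
compound 1 `Cc1ccc(-c2nc(N)c3cc(Cl)ccc3n2)cc1`: 14.5 ug/mL
compound 2 `Cc1ccc(-c2nc(NO)c3cc(Cl)ccc3n2)cc1`: 23.1 ug/mL

Compound 1 has the lowest number of the two, yet compound 2 lies within the scatter of it, so neither can be called the stronger inhibitor. Compound 3 `Cc1ccc(-c2nc(NOC(=O)c3ccccc3)c3cc(Cl)ccc3n2)cc1` differs from compound 1 by benzoyloxy in place of hydrogen on a nitrogen on an aromatic ring. Among the compounds with values here, the only measured step at that same nitrogen is a 1.6-fold higher number from compound 1 to compound 2 (0.20 log units; within the scatter), where a hydroxy group replaced the hydrogen. Nothing measured covers the benzoyloxy group itself. Because the related step of a 1.6-fold higher number from compound 1 to compound 2 (0.20 log units; within the scatter) stayed within the scatter, compound 3 is expected to stay near compound 1, with the step of a 1.4-fold higher number from compound 1 to compound 3 (0.14 log units; within the scatter) estimated as small and a wide range reflecting the untested group. Compound 3 is thus estimated at 20 ug/mL, between 8 ug/mL and 50 ug/mL.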

Compound 3, half-maximal inhibitory concentration: 12.1 ug/mL
Compound 3: the middle estimate sits 1.7-fold (0.22 log units) above what was measured; low and high end bracket the measured number.
By their numbers in this assay, from the lowest: compounds 3, 1 and 2 (each within the scatter of the next).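

In this assay, this nitrogen on the aromatic ring takes a whole benzoyloxy group in place of hydrogen with only a 1.2-fold lower number from compound 1 to compound 3 (0.08 log units; within the scatter). Adding benzoyl in place of the hydrogen on the oxygen gives a 1.9-fold lower number from compound 2 to compound 3 (0.28 log units; within the scatter), so all three compounds stay level, and an added aromatic ring shows no measurable effect at this position. No measured evidence here explains this result.

Still open, going by these compounds, is whether a smaller acetyl on the same oxygen would also stay level. It is also unknown whether an amine or a carboxylic acid on the benzoyl ring would move the number beyond the scatter.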